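The source may hold more compounds than are shown below. What is called first, only, known or untested is meant among the compounds shown, and "the series" means these compounds.

Compound 1 `COc1cccc(Oc2ccc3c(NCCCNCc4cc(F)ccc4OC)ccnc3c2)c1` is, in an ADME assay on HepG2 cells (Homo sapiens) for cytotoxicity, read by luminescence, CellTiter-Glo and ATP content, with a stated time of 72 h (on this read-out lower numbers stand for an effect already at smaller amounts and higher numbers for an effect only at larger amounts of compound), the compound with the highest of the three numbers on hand, giving 7100 nM. Its nearest neighbour on this read-out is compound 3 `COc1cccc(Oc2ccc3c(NCCCNCc4cccc(OC)c4O)ccnc3c2)c1`, which gives 5300 nM, and the step between them, a 1.3-fold lower number from compound 1 to compound 3 (0.13 log units; within the scatter), changes only the substituted benzyl group on the chain. Compound 2 `CCC(CC)c1ccc2c(NCCCNCc3cccc(OC)c3O)ccnc2c1` gives 410 nM, a number far lower than that of compound 1.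

The step to compound 4 `COc1ccc(F)cc1CNCCCNc1ccnc2cc(Oc3ccc(C(C)(C)C)cc3)ccc12` alters the group carried on the ether oxygen of the core: 4-(tert-butyl)phenyl in place of 3-methoxyphenyl on an oxygen on an aromatic ring.

Of the measured steps, a 13-fold higher number from compound 2 to compound 3 (1.11 log units; beyond the scatter) is the only one that touches the same position, and it is large, yet it exchanges an alkyl group for the whole 3-methoxyphenoxy unit rather than one aryl group for another. The step of a 1.3-fold lower number from compound 1 to compound 3 (0.13 log units; within the scatter) lies elsewhere in the molecule and stays within the scatter. Going by the values given here, no measured pair therefore shows what replacing one aryl group on this oxygen by another does, and the expectation is that the step from compound 1 to compound 4 stays within the scatter, with the estimate a 1.4-fold lower number from compound 1 to compound 4 (0.15 log units; within the scatter). Compound 4 is thus expected to give about 5000 nM in this assay, between 1500 nM and 16000 nM.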

Compound 4, half-maximal effective concentration: 7200 nM
For compound 4 the middle estimate is 1.4-fold (0.16 log units) below the measured one; measured number inside the range.
By their numbers in this assay, from the lowest: compound 2; then compounds 3, 1 and 4 (each within the scatter of the next).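

In this assay, going by these compounds alone, the exchange of 3-methoxyphenyl for 4-(tert-butyl)phenyl on an oxygen on an aromatic ring gives a 1.0-fold higher number from compound 1 to compound 4 (0.01 log units; within the scatter), the first direct reading of one aryl group replacing another at this place. The entering group has more heavy atoms, all of them carbon, and no hydrogen-bond acceptor, yet this difference leaves the two compounds within the scatter, unlike the large 13-fold higher number from compound 2 to compound 3 (1.11 log units; beyond the scatter), where the whole 3-methoxyphenoxy unit takes the place of pentan-3-yl. No measurement on hand explains why these two aryl groups read alike.

As far as these compounds go, it remains open whether an aryl group carrying an amine or a carboxylic acid, or a methyl group taking the place of the aryl group on this oxygen, would keep the number where it stands or bring it closer to that of compound 2. Also open, from the compounds shown here alone, is whether 4-(tert-butyl)phenyl would read the same way when the chain carries the 2-hydroxy-3-methoxyphenyl group of compound 3 instead of the benzyl group of compound 1.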